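Replacing a five-membered ring with a fluorinated six-membered ring

A few compounds are considered here, and "the series" means these few. Any claim that something is new, unique, unknown or untested is made for them only; others in the source may bear on it.

Measured compounds:
- compound 1, `OC[C@H]1OC(n2cnc3c(-c4ccco4)ncnc32)[C@H](O)[C@@H]1O`, 600 nM in a functional assay on CCRF-CEM cells (Homo sapiens) for inhibition; on this read-out lower numbers stand for stronger inhibition and higher numbers for weaker inhibition
- compound 2, `OC[C@H]1OC(n2cnc3c(-c4cc[nH]c4)ncnc32)[C@H](O)[C@@H]1O`, 1030 nM in this assay
- compound 3, `OC[C@H]1OC(n2cnc3c(-c4ccsc4)ncnc32)[C@H](O)[C@@H]1O`, 1640 nM in this assay

All three share one core and differ only in the aromatic ring attached to it. Compound 3 gives the highest number of the three: compound 2 sits nearest, within the scatter, while the gap to compound 1, a 2.7-fold higher number from compound 1 to compound 3 (0.44 log units; beyond the scatter), lies beyond it. Compound 4, `OC[C@H]1OC(n2cnc3c(-c4ccc(F)cc4)ncnc32)[C@H](O)[C@@H]1O`, has not yet been measured. Its difference from compound 3 is 4-fluorophenyl in place of thiophen-3-yl on an aromatic carbon.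

Two measured steps lead into compound 3: a 2.7-fold higher number from compound 1 to compound 3 (0.44 log units; beyond the scatter) and a 1.6-fold higher number from compound 2 to compound 3 (0.20 log units; within the scatter). Both show that swapping the ring at this position moves the number by a modest amount at most, and away from compound 1 the numbers rise. None of the measured compounds carries a six-membered ring of carbon only, so the shown steps bear on compound 4 only loosely. Continuing the trend away from compound 1, compound 4 is expected to give a somewhat higher number, a step of about a 1.8-fold higher number from compound 3 to compound 4 (0.26 log units; within the scatter), though one that may fall within the scatter. The estimate for compound 4 in this assay is 3000 nM, with a range from 1000 nM to 9000 nM.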

Compound 4, half-maximal inhibitory concentration: 700 nM
For compound 4 the middle estimate is 4.3-fold (0.63 log units) above the measured one; measured number below the stated range.
By their numbers in this assay, from the lowest: compounds 1, 4, 2 and 3 (each within the scatter of the next, the first and the last beyond it).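

In this assay, within the data shown here, this position accepts a six-membered aromatic ring of carbon only, something the earlier compounds, all with five-membered rings, could not show: a 2.3-fold lower number from compound 3 to compound 4 (0.37 log units; beyond the scatter), a step beyond the scatter. Against the other two rings the change stays within the scatter, at a 1.5-fold lower number from compound 2 to compound 4 (0.17 log units; within the scatter) and a 1.2-fold higher number from compound 1 to compound 4 (0.07 log units; within the scatter), which means the data place compound 4 in no clear order relative to compound 2 or compound 1. No supporting measurement is available to explain why the rings compare in this way.

The step from compound 3 to compound 4 changes the ring and adds the fluorine at once, and none of the compounds shown carries a plain phenyl ring, leaving the share of each in this result unknown. Also open is how the position responds to a 4-fluorophenyl replaced by a phenyl ring bearing a methoxy group, an amine or a carboxylic acid, none of which appears among these compounds.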